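The compounds below may be only part of what the source reports. "The series", "measured", "known", "first", "only" and "open" are said of these compounds alone.

In a functional assay on C6 cells (Rattus norvegicus) for cytotoxicity, read by MTT assay, with a stated time of 24 h, tested at 12 ug/mL (a lower number here means a stronger effect, a higher number a weaker effect of the compound at the concentration tested), the three measured compounds give the following numbers:

compound 1, `Cc1ccc(-c2cs/c(=N/NC(=O)CSc3nnnn3-c3ccccc3)n2-c2ccccc2)cc1`, gives 55.1%;
compound 2, `O=C(CSc1nnnn1-c1ccccc1)N/N=c1/scc(-c2ccc(F)cc2)n1-c1ccccc1`, gives 60%;
compound 3, `O=C(CSc1nnnn1-c1ccccc1)N/N=c1/scc(-c2ccccc2)n1-c1ccccc1`, gives 47.1%.

Compound 2 holds the highest of these three numbers. The step of a number 4.9 percentage points higher from compound 1 to compound 2 (within the scatter) lies within the scatter, so compound 2 and compound 1 cannot be told apart on this evidence. The step of a number 12.9 percentage points lower from compound 2 to compound 3 (beyond the scatter) is beyond the scatter and modest in size, while the step of a number 8 percentage points lower from compound 1 to compound 3 (within the scatter) again stays within the scatter.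

Compound 4, `O=C(CSc1ncccn1)N/N=c1/scc(-c2ccc(F)cc2)n1-c1ccccc1`, differs from compound 2 in one place: pyrimidin-2-yl in place of 1-phenyl-1H-tetrazol-5-yl on a sulfur. Going by the values given here, all three measured steps concern a substituent on an aromatic carbon of the aryl group; none of them alters the group on the sulfur, so no measured step bears directly on this change. In the absence of a guiding step, compound 4 is expected to give a number close to that of compound 2 in this assay, with a wide range. The expected step is no change at the digits printed from compound 2 to compound 4 (within the scatter), estimated to stay within the scatter. Compound 4 is thus estimated at 60%, between 42% and 78%.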

Compound 4, a percentage reported as activity, at one concentration (the size of the read-out at that concentration, not a potency): 77.4%
Compound 4: middle estimate off by 17.4 percentage points, on the low side, and the stated range covers the measured number.
By their numbers in this assay, from the lowest: compounds 3, 1 and 2 (each within the scatter of the next, the first and the last beyond it); then compound 4.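

The group on the sulfur proves to be a place where the read-out responds: in this assay, putting pyrimidin-2-yl in place of 1-phenyl-1H-tetrazol-5-yl gives a number 17.4 percentage points higher from compound 2 to compound 4 (beyond the scatter), which means a weaker effect at the concentration tested. This is the only change at this position among the compounds shown, and it replaces a group of two rings with a single ring that has fewer heavy atoms and fewer hydrogen-bond acceptors, so this one pair cannot show which of these differences matters. No measurement shown offers an explanation for the step.

From the compounds shown here alone, it remains open whether the step would carry over to the cores bearing methyl or hydrogen on the aryl group in place of fluoro. Going by these compounds, how a simple methyl, a longer alkyl chain, an amine or a carboxylic acid on the sulfur would read also remains open.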